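The compounds below may be only part of what the source reports. "The series", "measured", "known", "first", "only" and "open" are said of these compounds alone.

Three compounds sharing one core have been examined in a functional assay on A549 cells (Homo sapiens) for cytotoxicity, read by MTT assay, with a stated time of 24 h; a lower number here means a stronger inhibitor, a higher number a weaker inhibitor. Compound 1 `FC(F)(F)Oc1ccc(-c2cc(COc3ccccc3-c3nc4ccccc4s3)on2)cc1` gives 23900 nM. Compound 2 `Fc1ccc(-n2cc(COc3ccccc3-c3nc4ccccc4s3)nn2)cc1` gives 23300 nM, and compound 3 `FC(F)(F)C(F)(F)C(F)(F)C(F)(F)C(F)(F)C(F)(F)C(F)(F)C(F)(F)CCn1cc(COc2ccccc2-c2nc3ccccc3s2)nn1` gives 13100 nM. On these numbers compound 1 has the highest value of the three, yet its distance to compound 2 lies within the scatter, and so does its distance to compound 3, so the three values cannot be told apart with confidence in this assay.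

Compound 4 `Fc1ccccc1-c1cc(COc2ccccc2-c2nc3ccccc3s2)on1` differs from compound 1 in a single place: 2-fluorophenyl in place of 4-(trifluoromethoxy)phenyl on an aromatic carbon. Going by the values given here, no directly comparable pair among the measured compounds shows what a change of this kind does in this assay, and the three values at hand all lie close together. On that footing the account expects a step of a 1.2-fold lower number from compound 1 to compound 4 (0.08 log units; within the scatter) that stays within the scatter, with no clear direction either way. Compound 4 is therefore estimated to give 20000 nM in this assay, with an expected range from 8000 nM to 50000 nM, wide enough to cover the spread seen among the measured compounds.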

Compound 4, half-maximal inhibitory concentration: 22500 nM
Compound 4: middle estimate off by 1.1-fold (0.05 log units), on the low side, within the range that was stated.
By their numbers in this assay, from the lowest: compounds 3, 4, 2 and 1 (each within the scatter of the next).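

In this assay, going by these compounds alone, replacing 4-(trifluoromethoxy)phenyl with 2-fluorophenyl on the aromatic carbon next to the ring nitrogen gives a 1.1-fold lower number from compound 1 to compound 4 (0.03 log units; within the scatter), the first step in this set that changes a single place. Within the data shown here, this position therefore accepts a change from 11 heavy atoms to 7, and from 1 hydrogen-bond acceptor to 0, with no change in the number that can be told from the scatter, a point that the earlier compounds, which differ from one another in more than one place, could not show. No measurement at hand bears on why the number stays within the scatter across this change.

This single step alters the size of the group and the place and kind of its substituent together, leaving the contribution of each unresolved. Going by these compounds, it also remains open whether a plain phenyl ring, or a phenyl ring carrying an amine or a carboxylic acid, would move the number in this assay beyond the scatter in either direction, or whether this position simply has little bearing on the read-out.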